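Moving the phenyl on the amide aryl group

The compounds below may be only part of what the source reports. "The series", "measured", "known", "first", "only" and "open" are said of these compounds alone.

Among the measured compounds shown here, the two compounds measured so far share a long fluorinated chain that ends in a hydroxamic acid and carries an aryl amide at the other end. Compound 1 `CC(=O)Nc1ccc(NC(=O)C(F)(F)C(F)(F)C(F)(F)C(F)(F)C(F)(F)C(F)(F)C(=O)NO)cc1` gives 13000 nM in an assay on isolated protein for inhibition of histone deacetylase 7 (Homo sapiens), read by fluorescence; a higher number here means weaker binding, a lower number tighter binding. Compound 2 `O=C(NO)C(F)(F)C(F)(F)C(F)(F)C(F)(F)C(F)(F)C(F)(F)C(=O)Nc1cccc(-c2ccccc2)c1` gives 14000 nM in this assay, the highest of the two numbers, though the step of a 1.1-fold higher number from compound 1 to compound 2 (0.03 log units; within the scatter) lies within the scatter, so the two cannot be told apart. Compound 3 `O=C(NO)C(F)(F)C(F)(F)C(F)(F)C(F)(F)C(F)(F)C(F)(F)C(=O)Nc1ccccc1-c1ccccc1` keeps all atoms of compound 2 and changes only the arrangement: 2-phenylphenyl in place of 3-phenylphenyl on an amide-type nitrogen. For the measured compounds named here, no measured step covers this rearrangement, and the single step from compound 1 to compound 2 shows that a quite different aryl group on the amide nitrogen left the number essentially unchanged. The expectation for compound 3 is therefore a step of a 1.1-fold higher number from compound 2 to compound 3 (0.03 log units; within the scatter), none beyond the scatter. Compound 3 is expected to give about 15000 nM, within 6000 nM to 40000 nM.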

Compound 3, dissociation constant: 14000 nM
For compound 3 the middle estimate is 1.1-fold (0.03 log units) above the measured one; measured number inside the range.
By their numbers in this assay, from the lowest: compounds 1, 2 and 3 (each within the scatter of the next).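

In this assay the swap of 3-phenylphenyl for 2-phenylphenyl on the amide-type nitrogen gives no change at the digits printed from compound 2 to compound 3 (within the scatter) and so, for this pair with identical atoms, rearranging the two rings makes no readable difference. The comparison with the acetamide-bearing compound gives a 1.1-fold higher number from compound 1 to compound 3 (0.03 log units; within the scatter) and so all three aryl groups shown on this nitrogen cannot be told apart in this assay. Nothing available explains why these numbers stay level.

The compounds shown leave open whether any group on this nitrogen can move the number beyond the scatter, for instance a plain phenyl, an aryl ring carrying an amine or one carrying a carboxylic acid. They also leave open how much the chain itself matters, since a shorter chain, a longer chain or one with hydrogen in place of fluorine does not appear among them.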